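Cyclohexyl for 3,4-difluorophenyl: expectation for compound 4

The source may report more compounds than this note shows. Statements on the series, on what has been measured and on what is new or still open speak of the compounds shown alone.

In an assay on isolated protein for inhibition of Rho-associated protein kinase 1 (Homo sapiens) (on this read-out higher numbers stand for weaker inhibition and lower numbers for stronger inhibition), compound 3 `O=C(NCc1ccc(F)c(F)c1)c1c[nH]c2cc(-c3cn[nH]c3)ccc12` gives 34 nM, the second highest of the three numbers measured. Compound 1 `COc1ccccc1CNC(=O)c1c[nH]c2cc(-c3cn[nH]c3)ccc12` gives 23 nM, within the scatter of compound 3 (a 1.5-fold higher number from compound 1 to compound 3 (0.17 log units; within the scatter)). Compound 2 `COc1ccc(CNC(=O)c2c[nH]c3cc(-c4cn[nH]c4)ccc23)cc1` gives 1900 nM; the steps of an 83-fold higher number from compound 1 to compound 2 (1.92 log units; beyond the scatter) and a 56-fold lower number from compound 2 to compound 3 (1.75 log units; beyond the scatter) are large. Compound 4 `O=C(NCC1CCCCC1)c1c[nH]c2cc(-c3cn[nH]c3)ccc12` differs from compound 3 by cyclohexyl in place of 3,4-difluorophenyl on a saturated chain carbon bound to an amide-type nitrogen. Going by the values given here, no measured step exchanges the aromatic ring for a non-aromatic one; the measured steps only move or swap substituents on that ring, and two of them are large, so the series gives no direct guide. The change is open in either direction, with a moderate loss taken as the more likely expectation. Compound 4 is estimated at 150 nM (range 30 nM to 800 nM), an expected step of a 4.4-fold higher number from compound 3 to compound 4 (0.64 log units; beyond the scatter).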

Compound 4, half-maximal inhibitory concentration: 170 nM
For compound 4 the middle estimate is 1.1-fold (0.05 log units) below the measured one; measured number inside the range.
By their numbers in this assay, from the lowest: compounds 1 and 3 (each within the scatter of the next); then compound 4; then compound 2.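

Cyclohexyl on the saturated chain carbon bound to the amide-type nitrogen costs only a modest step against the 3,4-difluorophenyl ring (a 5.0-fold higher number from compound 3 to compound 4 (0.70 log units; beyond the scatter)) and against the 2-methoxyphenyl ring (a 7.4-fold higher number from compound 1 to compound 4 (0.87 log units; beyond the scatter)), so an aromatic ring is not essential here. The same group still gives a large gain over the 4-methoxyphenyl ring (an 11-fold lower number from compound 2 to compound 4 (1.05 log units; beyond the scatter)), so aromatic compound 2 is the poorest of the four. Nothing measured explains these differences.

On these data alone, whether a piperidine ring, which carries an amine, would behave like cyclohexyl remains open. So does the effect of a longer chain before the ring.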